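The source may report more compounds than this note shows. Statements on the series, on what has been measured and on what is new or still open speak of the compounds shown alone.

Two compounds share one core and differ only in the halogen on the aromatic ring. Compound 1 `O=C(O)/C(S)=C/c1ccc(Br)cc1` gives 1500 nM in an assay on isolated protein for inhibition of Calpain-1 catalytic subunit (Sus scrofa), read by FRET; on this read-out lower numbers stand for stronger inhibition and higher numbers for weaker inhibition. Compound 2 `O=C(O)/C(S)=C/c1ccc(Cl)cc1` gives 2600 nM in this assay, which is the highest of the two numbers seen so far; its nearest neighbour is compound 1, and the step of a 1.7-fold higher number from compound 1 to compound 2 (0.24 log units; within the scatter) lies within the scatter of the measurement. Compound 3 `O=C(O)/C(S)=C/c1ccc(F)cc1` carries the change (fluoro in place of chloro on an aromatic carbon). For the measured compounds named here, the only measured step that bears on this kind of swap is the one from bromo to chloro, and it stayed within the scatter, so a further move down the halogen series is expected to give at most a modest shift upward in this assay, if any beyond the scatter. The expected step is a 1.5-fold higher number from compound 2 to compound 3 (0.19 log units; within the scatter). Compound 3 is therefore estimated at 4000 nM, with a likely range from 1800 nM to 9000 nM.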

Compound 3, half-maximal inhibitory concentration: 6900 nM
Estimate against measurement, compound 3: 1.7-fold (0.24 log units) below; measured number inside the range.
By their numbers in this assay, from the lowest: compounds 1 and 2 (each within the scatter of the next); then compound 3.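

At this place on the aromatic ring, the choice of halogen does register in this assay: fluoro in place of chloro gives a 2.7-fold higher number from compound 2 to compound 3 (0.42 log units; beyond the scatter) and so clears the scatter, which the swap of bromo for chloro did not do. Fluoro in place of bromo gives a 4.6-fold higher number from compound 1 to compound 3 (0.66 log units; beyond the scatter) and leaves compound 3 the weakest of the three, while compound 1 and compound 2 still cannot be told apart. No measurement at hand accounts for fluoro standing apart from bromo and chloro.

The compounds shown leave open how iodo, a methyl, a methoxy or an amine at this same place would compare with the halogens. They also leave open whether the swap of chloro for fluoro would have the same size on a core carrying an amide in place of the carboxylic acid.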